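This account rests on a few compounds, and the source may have more. Where it says the series, first, only, none or still open, it means among the compounds named here.

Working notes on a small set of compounds built on one shared core. Compound 1 `CC1(C)[C@@H]2CC3=NCC(=O)O[C@@]3(C)[C@H]1C2` is the simplest member. Compound 2 `CC(C)(C)OC(=O)n1cnc(C[C@H]2N=C3C[C@H]4C[C@H](C4(C)C)[C@@]3(C)OC2=O)c1` and compound 3 `CC(C)(C)OC(=O)NCCCC[C@H]1N=C2C[C@H]3C[C@H](C3(C)C)[C@@]2(C)OC1=O` carry larger substituents on the same core. All three were run in an ADME assay on McCoy cells (Mus musculus) for antiproliferative activity, read by sulforhodamine B assay, with a stated time of 48 h; a lower number here means a stronger inhibitor, a higher number a weaker inhibitor.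

Compound 1 gives > 900000 nM in this assay, which is a limit of the assay and not a number. Compound 2 gives > 1300000 nM in this assay, again a limit. Compound 3 gives > 1300000 nM in this assay, also a limit. Compound 1 thus stands at the limit of > 900000 nM in this assay, at which 1 of the 3 values shown sits. The remaining two values sit at the limit of > 1300000 nM in this assay, at which 2 of the 3 values shown sit. Within the data shown here, no compound shows a measured number, so no step between measured compounds can be drawn and no ranking among the three is possible.

Compound 4 `CC1(C)[C@@H]2CC3=N[C@@H](CCC(=O)O)C(=O)O[C@@]3(C)[C@H]1C2` is not yet measured. It differs from compound 1 by 2-carboxyethyl in place of hydrogen on a saturated ring carbon. With every measured value a limit, no step size can be anchored on this set; the step is expected to be none beyond the scatter, a step that the limit leaves unreadable from compound 1 to compound 4, and a further limit rather than a number is the likeliest outcome. Compound 4 is expected at 1000000 nM in this assay, with a range from 300000 nM to 3000000 nM.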

Compound 4, half-maximal inhibitory concentration: > 1200000 nM
Compound 4: a limit, no number; the forecaster's own chance of this, stated with the estimate: 90%; middle value at least 1.2-fold (0.07 log units) from the limit.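

Compound 1 and compound 4 both stand at limits of this assay and not at numbers, so the step from 2-carboxyethyl in place of hydrogen on a saturated ring carbon cannot be read. The compounds shown leave open whether any substituent on the shared core gives a measurable antiproliferative value in this assay.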